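Swapping 3-formylphenyl for 4-formylphenyl in a weak set

The compounds below may be only part of what the source reports. "The series", "measured", "known", "first", "only" and "open" are said of these compounds alone.

Of the compounds shown here, three sharing one core have been tested in a functional assay on HepG2 cells (Homo sapiens) for inhibition, read by MTT assay, with a stated time of 48 h; on this read-out lower numbers stand for stronger inhibition and higher numbers for weaker inhibition. Compound 1 `COc1cc(C(=O)/C=C/c2ccc(O)c(O)c2)cc(OC)c1OC`, which carries 3,4-dihydroxyphenyl, gives 14900 nM. Compound 2 `COc1cc(C(=O)/C=C/c2ccc([N+](=O)[O-])cc2)cc(OC)c1OC` gives > 100000 nM, which is a limit of the assay and not a number. Compound 3 `COc1cc(C(=O)/C=C/c2cccc(C=O)c2)cc(OC)c1OC` gives > 100000 nM, which is also only a limit. Compound 3 therefore stands at the limit of > 100000 nM in this assay, at which 2 of the 3 values shown sit.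

Compound 4 `COc1cc(C(=O)/C=C/c2ccc(C=O)cc2)cc(OC)c1OC` has the same atoms as compound 3, joined differently, with 4-formylphenyl in place of 3-formylphenyl on a double-bonded chain carbon bound to a double-bonded chain carbon. Within the data shown here, the one measured step that bears on this replaced 3,4-dihydroxyphenyl with 3-formylphenyl and gave an at least 6.7-fold higher number from compound 1 to compound 3 (0.82 log units; beyond the scatter), which is beyond the scatter. Compound 4 keeps a formyl group and, like compound 3, has no 3,4-dihydroxyphenyl, so a similarly weak result is expected. No change beyond the scatter is expected, and the estimated step is a number no higher from compound 3 to compound 4 (the limit leaves the size open). The estimate for compound 4 is 100000 nM, with an expected range of 30000 nM to 200000 nM.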

Compound 4, half-maximal inhibitory concentration: > 100000 nM
Compound 4 gave a limit, no number; the forecaster's own chance of this, stated with the estimate: 70%; the middle value sits exactly at the limit.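

Moving the formyl group, with 4-formylphenyl in place of 3-formylphenyl, leaves compound 4 at a limit in this assay, so the steps to it from compound 3 and from compound 2 cannot be read. Replacing 3,4-dihydroxyphenyl with 4-formylphenyl gives an at least 6.7-fold higher number from compound 1 to compound 4 (0.82 log units; beyond the scatter), so neither formyl placement shown here gives a readable number as compound 1 does. Most of this small set now rests at one ceiling: the limit of > 100000 nM in this assay, at which 3 of the 4 values shown sit.

Going by these compounds, only compound 1 gives a true number, so how far apart compound 2, compound 3 and compound 4 really lie stays unknown. On these data alone, it also remains open whether an amine or a carboxylic acid in place of the formyl group would give a readable value.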